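The source may hold more compounds than are shown below. What is called first, only, known or untested is meant among the compounds shown, and "the series" means these compounds.

Measured compounds in an ADME assay on Huh-5-2 cells (Homo sapiens) for cytotoxicity, read by WST assay, with a stated time of 3 days; on this read-out lower numbers stand for higher toxicity in this test and higher numbers for lower toxicity in this test:
Compound 1, `O=c1c(O)c(-c2ccccc2)oc2cc(OCc3ccccc3[N+](=O)[O-])cc(O)c12`: 32000 nM.
Compound 2, `N#Cc1cccc(COc2cc(O)c3c(=O)c(O)c(-c4ccccc4)oc3c2)c1`: 72000 nM.
Compound 3, `O=c1c(O)c(-c2ccccc2)oc2cc(OCc3ccc(Br)cc3)cc(O)c12`: the value is a limit, > 100000 nM.

Within the data shown here, compound 3 is the one compound whose result is a limit rather than a number, (the limit of > 100000 nM in this assay, at which 1 of the 3 values shown sits). The measured steps are a 2.3-fold higher number from compound 1 to compound 2 (0.35 log units; beyond the scatter) and an at least 3.1-fold higher number from compound 1 to compound 3 (0.49 log units; beyond the scatter), both beyond the scatter, while an at least 1.3-fold higher number from compound 2 to compound 3 (0.14 log units; that floor lies within the scatter) rests on that limit and its true size cannot be placed against the scatter.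

Compound 4, `Cc1ccc(COc2cc(O)c3c(=O)c(O)c(-c4ccccc4)oc3c2)cc1`, differs from compound 3 by methyl in place of bromo on an aromatic carbon. Among the measured compounds shown here, none of the measured steps tests this kind of change: each of them exchanges the whole ring on the saturated chain carbon bound to an oxygen on an aromatic ring, whereas here only one group on that ring is exchanged and the ring itself and its attachment are kept. The two steps beyond the scatter both run toward the limit, and compound 3 already sits at it. Nothing in the measured set points to a return toward the numbers of compound 1 or compound 2, so compound 4 is expected to remain at or above the limit, the step that the limit leaves unreadable from compound 3 to compound 4 being the expected outcome. Compound 4 is therefore estimated at 150000 nM, within 60000 nM to 400000 nM, with a fair chance that only a limit is recorded again.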

Compound 4, half-maximal cytotoxic concentration: 88000 nM
Estimate against measurement, compound 4: 1.7-fold (0.23 log units) above; the measured number falls inside the stated range.
By their numbers in this assay, from the lowest: compound 1; then compounds 2 and 4 (each within the scatter of the next). At a limit, above all of these: compound 3.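

In this assay, among these compounds, methyl in place of bromo on an aromatic carbon, para to a large group, is the one exchange that keeps the ring, and compound 4 gives 88000 nM, a number and not a limit. The size of this exchange stays unreadable, as an at least 1.1-fold lower number from compound 3 to compound 4 (0.05 log units; that floor lies within the scatter) rests on a limit held by compound 3: the limit of > 100000 nM in this assay, at which 1 of the 4 values shown sits. Against the other ring exchanges, the result gives a 1.2-fold higher number from compound 2 to compound 4 (0.09 log units; within the scatter), so 4-methylphenyl and 3-cyanophenyl are not separated in this test, while a 2.8-fold higher number from compound 1 to compound 4 (0.44 log units; beyond the scatter) leaves compound 1 set apart from compound 4 as well as from compound 2 and compound 3.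

Still open, from the compounds shown here alone, is how an amine or a carboxylic acid in place of the methyl on this aromatic carbon would read in this assay. Also open, going by these compounds, is whether a longer chain between the ring and the oxygen would keep the numbers of compound 2 and compound 4 or move toward the number of compound 1.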